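This account rests on a few compounds, and the source may have more. Where it says the series, first, only, none or still open, it means among the compounds named here.

Measured so far:
Compound 1, `Cc1ccc(-c2nn(-c3ccccc3)cc2CNc2ccccc2)cc1`: in an ADME assay on BHK-21 cells (Mesocricetus auratus) for cytotoxicity, read by MTT assay, with a stated time of 72 h (on this read-out lower numbers stand for higher toxicity in this test and higher numbers for lower toxicity in this test), compound 1 gives only a limit, > 100000 nM.
Compound 2, `FC(F)(F)c1ccc(-c2nn(-c3ccccc3)cc2CNc2ccc(Br)cc2)cc1`: in this assay compound 2 gives 28000 nM.

Compound 1 thus stands at the top of the numbers shown; its value is a limit rather than a number, since it sits on (the limit of > 100000 nM in this assay, at which 1 of the 2 values shown sits). Within the data shown here, compound 2 differs from compound 1 in more than one place, so the gap between them is not a single step; the two values show only that compound 2 reached a measured number where compound 1 did not. Compound 3, `Cc1ccc(-c2nn(-c3ccccc3)cc2CNc2ccc(Cl)cc2)cc1`, is not yet measured. It differs from compound 1 in one place: chloro in place of hydrogen on an aromatic carbon. Among the measured compounds shown here, with no measured single step to lean on, the change expected in this assay is a modest shift toward higher toxicity, an at least 1.6-fold lower number from compound 1 to compound 3 (0.22 log units; that floor lies within the scatter), not clearly beyond the scatter. Compound 3 is therefore expected to give about 60000 nM, within 20000 nM to 200000 nM.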

Compound 3, half-maximal cytotoxic concentration: > 100000 nM
Compound 3 ended at the assay's limit (the forecaster's own chance of this, stated with the estimate: 40%); middle value at least 1.6-fold (0.22 log units) away from the limit.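

No step can be read from compound 1 to compound 3 in this assay, since both compounds give a limit rather than a number: the limit of > 100000 nM in this assay, at which 2 of the 3 values shown sit.

The compounds shown leave open whether chloro in place of hydrogen here changes toxicity in this test at all.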